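Quinone for dihydroxyphenyl on a pyrazole sulfonamide series

The compounds below may be only part of what the source reports. "The series", "measured", "known", "first", "only" and "open" are said of these compounds alone.

In a functional assay on cells (Cancer cell lines, Homo sapiens) for cytotoxicity, read by sulforhodamine B assay, with a stated time of 48 h (on this read-out lower numbers stand for stronger inhibition of growth and higher numbers for weaker inhibition of growth), compound 1 `NS(=O)(=O)c1ccc(-n2nc(-c3ccc(Cl)cc3)cc2-c2cc(O)ccc2O)cc1` gives 12000 nM. Compound 3 `NS(=O)(=O)c1ccc(-n2nc(-c3ccc(Cl)cc3)cc2C2=CC(=O)C=CC2=O)cc1` gives 23100 nM in this assay; the change made is a group of 8 heavy atoms (6 carbon, 2 oxygen; one six-membered non-aromatic ring of carbon only) in place of a group of 8 heavy atoms (6 carbon, 2 oxygen; one six-membered aromatic ring of carbon only), on an aromatic carbon, and the step is a 1.9-fold higher number from compound 1 to compound 3 (0.28 log units; within the scatter). Compound 2 `CC(=O)NS(=O)(=O)c1ccc(-n2nc(-c3ccccc3)cc2-c2cc(O)ccc2O)cc1` gives 78100 nM in this assay, the highest of the three numbers; the difference between the cores of compound 1 and compound 2 is not broken down here. Compound 4 `CC(=O)NS(=O)(=O)c1ccc(-n2nc(-c3ccccc3)cc2C2=CC(=O)C=CC2=O)cc1` is not yet measured. It carries the same kind of change as compound 3, namely (a group of 8 heavy atoms (6 carbon, 2 oxygen; one six-membered non-aromatic ring of carbon only) in place of a group of 8 heavy atoms (6 carbon, 2 oxygen; one six-membered aromatic ring of carbon only), on an aromatic carbon); around the place, the neighbouring ring atom bears a large group rather than a 4-sulfamoylphenyl group, and the ring atom two bonds away bears a phenyl group rather than a 4-chlorophenyl group. Because a 1.9-fold higher number from compound 1 to compound 3 (0.28 log units; within the scatter) stayed within the scatter, he expects a step of similar size, a 1.9-fold higher number from compound 2 to compound 4 (0.28 log units; within the scatter). For compound 4 he estimates 150000 nM in this assay, between 60000 nM and 400000 nM.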

Compound 4, concentration for 50% growth inhibition: 90000 nM
Compound 4: the middle estimate sits 1.7-fold (0.22 log units) above what was measured, and the stated range covers the measured number.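

In this assay, putting the non-aromatic ring in place of the 2,5-dihydroxyphenyl group gives a 1.2-fold higher number from compound 2 to compound 4 (0.06 log units; within the scatter). Set beside the earlier step, the same change shows no detectable difference between the two cores: the same change on two cores in this assay, a 1.9-fold higher number (0.28 log units; within the scatter) from compound 1 to compound 3 and a 1.2-fold higher number (0.06 log units; within the scatter) from compound 2 to compound 4, 1.7-fold (0.22 log units) apart, within the scatter of two such steps. Within the data shown here, with only two pairs, and both steps within the scatter, this shows that the change left the number about where it was on these two cores, not that it would do so on any other core.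

The compounds shown leave open how the gap between the cores of compound 1 and compound 2 divides between the chlorine and the acetyl group, as these two features change together. Also open, as far as these compounds go, is whether the step would hold on a core carrying an amine or a carboxylic acid on the phenyl group.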